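The source may hold more compounds than are shown below. What is called first, only, known or untested is meant among the compounds shown, and "the series" means these compounds.

Working notes on the series, read in a functional assay on NALM-6 cells (Homo sapiens) for cytotoxicity, with a stated time of 72 h; on this read-out lower numbers stand for an effect already at smaller amounts and higher numbers for an effect only at larger amounts of compound. Compound 1 (`COc1ccc(/C=C/[C@@](C)(/C=C/c2ccc(O)c(/C=C/C#N)c2)CCC=C(C)C)cc1`) gives 16500 nM. Compound 2 (`CCOC(=O)/C=C/c1cc(/C=C/[C@](C)(/C=C/c2ccc(OC)cc2)CCC=C(C)C)ccc1O`) gives > 43400 nM, which is a limit and not a number. Compound 3 (`CCOC(=O)/C(C)=C/c1cc(/C=C/[C@](C)(/C=C/c2ccc(OC)cc2)CCC=C(C)C)ccc1O`) gives > 43400 nM, which is again a limit. Compound 3 therefore stands at the limit of > 43400 nM in this assay, at which 2 of the 3 values shown sit.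

Compound 4 (`COc1ccc(/C=C/[C@@](C)(/C=C/c2ccc(O)c(/C=C/C(=O)OC(C)(C)C)c2)CCC=C(C)C)cc1`) carries 2-(tert-butoxycarbonyl)ethenyl in place of 2-(ethoxycarbonyl)prop-1-en-1-yl on an aromatic carbon, ortho to a hydroxy group: 2-(tert-butoxycarbonyl)ethenyl in place of 2-(ethoxycarbonyl)prop-1-en-1-yl on an aromatic carbon.

Among the compounds with values here, three measured steps bear on this change. Exchange of the cyano-bearing chain for an ester-bearing chain gave an at least 2.6-fold higher number from compound 1 to compound 2 (0.42 log units; beyond the scatter) and an at least 2.6-fold higher number from compound 1 to compound 3 (0.42 log units; beyond the scatter), both at least modest. The closest comparison among the esters is a step that the two limits leave unreadable from compound 2 to compound 3, so it gives no size. Compound 4 remains an ester, so no step beyond the scatter is expected, and a further limit reading is likely. The expected change is a step that the limit leaves unreadable from compound 3 to compound 4, an estimated step with no clear direction. For compound 4 the estimated value is 45000 nM, with an expected range from 20000 nM to 100000 nM.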

Compound 4, half-maximal effective concentration: > 43400 nM
Compound 4 gave a limit, no number (the forecaster's own chance of this, stated with the estimate: 65%); the middle value lies beyond the limit too.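

With tert-butoxycarbonyl in the chain on this aromatic carbon, ortho to a hydroxy group, a third ester reaches the same limit in this assay: the limit of > 43400 nM in this assay, at which 3 of the 4 values shown sit. The change from cyano to tert-butoxycarbonyl gave an at least 2.6-fold higher number from compound 1 to compound 4 (0.42 log units; beyond the scatter), so the step already seen with the ethyl esters also appears with tert-butyl on the ester oxygen, and among the compounds shown only compound 1, the nitrile, gives a number rather than a limit. The steps among compound 2, compound 3 and compound 4 cannot be read, as all three values are limits.

Any ordering of the three esters therefore stays open. Also open, as far as these compounds go, is whether a carboxylic acid or a primary amide at the end of the same chain would give a number, as the nitrile does, or another limit.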